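A few compounds are considered here, and "the series" means these few. Any claim that something is new, unique, unknown or untested is made for them only; others in the source may bear on it.

Measured so far:
compound 1, `CC(C)=CCC/C(C)=C/CC/C(C)=C/CC[C@@H]1[C@@]2(C)CC/C(=N\OCc3cn(-c4ccc(F)cc4)nn3)C(C)(C)[C@@H]2CC[C@@]1(C)O`, gives 21400 nM in a functional assay on HeLa cells (Homo sapiens) for cytotoxicity, read by MTT assay, with a stated time of 48 h; a lower number here means a stronger inhibitor, a higher number a weaker inhibitor.
compound 2, `CC(C)=CCC/C(C)=C/CC/C(C)=C/CC[C@@H]1[C@@]2(C)C/C(=C\c3ccc(OCc4cn(-c5ccccc5)nn4)cc3)C(=O)C(C)(C)[C@@H]2CC[C@@]1(C)O`, gives 36300 nM in this assay.

Compound 2 and compound 1 are the only two measured, and their values sit within the usual scatter of each other, so nothing can be said about which is the stronger. Compound 3, `CC(C)=CCC/C(C)=C/CC/C(C)=C/CC[C@@H]1[C@@]2(C)C/C(=C\c3ccc(OCc4cn(-c5cccc([N+](=O)[O-])c5)nn4)cc3)C(=O)C(C)(C)[C@@H]2CC[C@@]1(C)O`, differs from compound 2 by one change: nitro in place of hydrogen on an aromatic carbon. Among the compounds with values here, no measured pair shows what such a change does here. A nitro group added to the phenyl of the triazole is expected to leave the value about where compound 2 sits, with a 1.2-fold lower number from compound 2 to compound 3 (0.08 log units; within the scatter) as the expected step. Compound 3 is therefore estimated at 30000 nM, between 12000 nM and 75000 nM.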

Compound 3, half-maximal inhibitory concentration: 32900 nM
The estimate for compound 3 lay 1.1-fold (0.04 log units) below the measured number; measured number inside the range.
By their numbers in this assay, from the lowest: compounds 1, 3 and 2 (each within the scatter of the next).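

Phenyl to 3-nitrophenyl is the first change in one place that can be read here, and it gives a 1.1-fold lower number from compound 2 to compound 3 (0.04 log units; within the scatter) in this assay. At this position on the aromatic ring, then, adding a nitro group leaves no difference that can be told from ordinary assay scatter. No supporting measurement bears on why this is so.

From the compounds shown here alone, whether an amine or a carboxylic acid at the same position would also leave the value unchanged remains open. So does the outcome of placing the nitro group elsewhere on that ring.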